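From Methyl to Cyano in a Cytotoxicity Series

The source may hold more compounds than are shown below. What is called first, only, known or untested is meant among the compounds shown, and "the series" means these compounds.

Three amides sharing one core have been measured in a toxicity assay on THP-1 cells (Homo sapiens) for inhibition; a lower number here means that less compound is tolerated, a higher number that more compound is tolerated. Compound 1 `Cn1c(-c2ccccc2F)cnc1NC(=O)c1ccc(F)cc1` gives > 100000 nM, which is a limit of the assay and not a number. Compound 2 `Cn1c(-c2ccccc2Cl)cnc1NC(=O)c1ccc(F)cc1` gives > 50000 nM, again only a limit. Within the data shown here, compound 3 `Cc1ccc(-c2cnc(NC(=O)c3ccc(F)cc3)n2C)cc1` gives 60000 nM, the only true number among the three, so its standing against the other two can be read only in part.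

Compound 4 `Cn1c(-c2ccc(C#N)cc2)cnc1NC(=O)c1ccc(F)cc1` differs from compound 3 in one place, with cyano in place of methyl on an aromatic carbon, para to a large group: cyano in place of methyl on an aromatic carbon. Among the measured compounds shown here, no measured compound carries a cyano group, so no step shows this change directly. The nearest evidence is an at least 1.6-fold lower number from compound 1 to compound 3 (0.22 log units; that floor lies within the scatter), a change of 2-fluorophenyl to 4-methylphenyl. The remaining steps give no size: a step that the two limits leave unreadable from compound 1 to compound 2 and a step that the limit leaves unreadable from compound 2 to compound 3. All three compounds nevertheless sit at high concentrations in this assay, and nothing measured points to a large move when this group is altered.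

No shift beyond the scatter is therefore expected, and the estimated change is a 1.2-fold higher number from compound 3 to compound 4 (0.07 log units; within the scatter). The value expected for compound 4 is 70000 nM. The estimated range for compound 4 runs from 30000 nM to 150000 nM.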

Compound 4, half-maximal cytotoxic concentration: > 50000 nM
Compound 4 gave a limit, no number; the forecaster's own chance of this, stated with the estimate: 45%; the middle value does not contradict the limit.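

In this assay compound 4 gives > 50000 nM, which is a limit of the assay and not a number. Among these compounds, no step from compound 1, compound 2 or compound 3 to compound 4 can be read. The compounds shown leave open whether cyano in place of methyl on an aromatic carbon moves this read-out at all, and in which direction.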